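Methylamino versus cyclobutylamino on a weak adenosine scaffold

The compounds below may be only part of what the source reports. "The series", "measured", "known", "first", "only" and "open" are said of these compounds alone.

The measured compounds:
compound 1, `CNc1nc(-c2ccccc2)nc2c1nnn2Cc1ccccc1Cl`, gives 191000000 nM in an assay on isolated protein for binding affinity to adenosine receptor A1 (Bos taurus); a lower number here means a stronger inhibitor, a higher number a weaker inhibitor;
compound 2, `Clc1ccccc1Cn1nnc2c(NC3CCC3)nc(-c3ccccc3)nc21`, gives 24000000 nM in this assay;
compound 3, `c1ccc(Cn2nnc3c(NC4CCC4)nc(-c4ccccc4)nc32)cc1`, gives 5000000 nM in this assay.

Compound 2 and compound 3 differ only in the benzyl part: hydrogen in place of chloro on an aromatic carbon. For the measured compounds named here, that change gives a 4.8-fold lower number from compound 2 to compound 3 (0.68 log units; beyond the scatter), so compound 3 stands with the lowest number of the three, and no compound measured here binds tightly.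

Compound 2 and compound 1 share the chlorobenzyl group and differ at the amine: methyl in place of cyclobutyl on a nitrogen on an aromatic ring. That change gives an 8.0-fold higher number from compound 2 to compound 1 (0.90 log units; beyond the scatter).

Compound 4, `CNc1nc(-c2ccccc2)nc2c1nnn2Cc1ccccc1`, is not yet measured. Relative to compound 3 it carries the same change: methyl in place of cyclobutyl on a nitrogen on an aromatic ring. The place is the same, and the surrounding groups are the same apart from the chlorine that separates the two pairs. Going by the values given here, compound 4 is therefore expected to show about an 8.0-fold higher number from compound 3 to compound 4 (0.90 log units; beyond the scatter), because an 8.0-fold higher number from compound 2 to compound 1 (0.90 log units; beyond the scatter) is the only guide available for this change. The estimate for compound 4 in this assay is 40000000 nM, expected to fall between 15000000 nM and 110000000 nM.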

Compound 4, inhibition constant: 353000000 nM
Beside the measured number, compound 4's estimate is 8.8-fold (0.95 log units) below it; measured number outside the range, above it.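

In this assay, replacing cyclobutylamino with methylamino gives a higher number on both cores, so the direction of the change carries over, but its size does not, with a 71-fold higher number from compound 3 to compound 4 (1.85 log units; beyond the scatter) set against a smaller step on the chlorobenzyl core: the same change on two cores in this assay, an 8.0-fold higher number (0.90 log units; beyond the scatter) from compound 2 to compound 1 and a 71-fold higher number (1.85 log units; beyond the scatter) from compound 3 to compound 4, 8.9-fold (0.95 log units) apart, beyond the scatter of two such steps

Removing the chlorine also depends on the amine: it gives a lower number with cyclobutylamino, whereas with methylamino the step is a 1.8-fold higher number from compound 1 to compound 4 (0.27 log units; within the scatter): the same change on two cores in this assay, a 4.8-fold lower number (0.68 log units; beyond the scatter) from compound 2 to compound 3 and a 1.8-fold higher number (0.27 log units; within the scatter) from compound 1 to compound 4, 8.9-fold (0.95 log units) apart, beyond the scatter of two such steps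

Together, these steps show that the two changes do not simply add up across these four compounds, so a step measured on one core gave a poor estimate of its size on the other, but they do not show why.

The compounds shown leave open what a propyl chain or a cyclopentyl ring on the same nitrogen would give on each core. They also leave open whether the same dependence would appear with fluoro or methoxy in place of chloro.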